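The source may report more compounds than this note shows. Statements on the series, on what has been measured and on what is new or still open speak of the compounds shown alone.

Measured compounds:
compound 1 `CCCCN(C)c1nc(C(F)(F)F)ccc1CNC(=O)C(C)c1ccc(NS(C)(=O)=O)c(F)c1` gives 21.3 nM in a functional assay on CHO-K1 cells for antagonist activity at transient receptor potential cation channel subfamily V member 1 (Homo sapiens), read by FLIPR; on this read-out higher numbers stand for weaker inhibition and lower numbers for stronger inhibition
compound 2 `CC(C(=O)NCc1ccc(C(F)(F)F)nc1N1CCC(Cc2cc(F)cc(F)c2)CC1)c1ccc(NS(C)(=O)=O)c(F)c1` gives 24 nM in this assay

Compound 2 has the higher of the two numbers in this assay, yet its gap to compound 1 sits within the scatter, so the two read alike. Compound 3 `CC(C(=O)NCc1ccc(C(F)(F)F)nc1N1CCC(CN(C)C)CC1)c1ccc(NS(C)(=O)=O)c(F)c1` differs from compound 2 by one change: dimethylamino in place of 3,5-difluorophenyl on a saturated chain carbon bound to a saturated ring carbon. Going by the values given here, no measured pair shows this kind of change, so nothing here calibrates it. A sizable step toward weaker inhibition seems more likely than none. Compound 3 is therefore expected at 250 nM, within 50 nM to 1500 nM, meaning an estimated step of a 10-fold higher number from compound 2 to compound 3 (1.02 log units; beyond the scatter).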

Compound 3, half-maximal inhibitory concentration: 426 nM
Beside the measured number, compound 3's estimate is 1.7-fold (0.23 log units) below it; the measured number falls inside the stated range.
By their numbers in this assay, from the lowest: compounds 1 and 2 (each within the scatter of the next); then compound 3.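

In this assay, the place on a saturated chain carbon bound to a saturated ring carbon proves sensitive: dimethylamino in place of 3,5-difluorophenyl gives an 18-fold higher number from compound 2 to compound 3 (1.25 log units; beyond the scatter). The step of a 20-fold higher number from compound 1 to compound 3 (1.30 log units; beyond the scatter) is also large, with 4-((dimethylamino)methyl)piperidin-1-yl in place of butyl(methyl)amino on an aromatic carbon. Nothing measured here gives a reason for this weakening.

Still open, on these data alone, is whether the weakening follows the departing aromatic ring or the entering nitrogen. A cyclohexyl or a piperidin-1-yl on the same carbon would help separate the two.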